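Changing the Group on the Sulfonyl Sulfur: Compound 2 to Compound 4

A few compounds are considered here, and "the series" means these few. Any claim that something is new, unique, unknown or untested is made for them only; others in the source may bear on it.

Of the compounds shown here, three sharing one core have been measured in an assay on isolated protein for inhibition of kynurenine 3-monooxygenase (Rattus norvegicus); a higher number here means a weaker inhibitor, a lower number a stronger inhibitor. Compound 2 `Nc1ccc(S(=O)(=O)Nc2nc(-c3cccc([N+](=O)[O-])c3)cs2)cc1` gives 40 nM, the lowest of the three numbers, though compound 3 `Cc1ccc(S(=O)(=O)Nc2nc(-c3cccc([N+](=O)[O-])c3)cs2)cc1` with 48 nM and compound 1 `Cc1ccc(-c2csc(NS(=O)(=O)c3ccc(C)cc3)n2)cc1` with 76 nM both sit within the usual scatter of it. Going by the values given here, the one measured step at the ring bound to the sulfonyl sulfur, a 1.2-fold higher number from compound 2 to compound 3 (0.08 log units; within the scatter), changed almost nothing. Compound 1 and compound 3 differ on the other ring, and their two values also lie within the scatter of each other.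

Compound 4 `O=[N+]([O-])c1cccc(-c2csc(NS(=O)(=O)c3ccc(Cl)c(Cl)c3)n2)c1` has not yet been measured. It differs from compound 2 by 3,4-dichlorophenyl in place of 4-aminophenyl on a sulfonyl sulfur. Among the compounds with values here, only the step from compound 2 to compound 3 bears on this change, and it stayed within the scatter, so for compound 4 a step of a 1.1-fold higher number from compound 2 to compound 4 (0.05 log units; within the scatter) is expected, nothing beyond the scatter in either direction. Compound 4 is therefore estimated at 45 nM, with a range from 18 nM to 110 nM.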

Compound 4, half-maximal inhibitory concentration: 120 nM
Estimate against measurement, compound 4: 2.7-fold (0.43 log units) below; measured number outside the range, above it.
By their numbers in this assay, from the lowest: compounds 2, 3, 1 and 4 (each within the scatter of the next, the first and the last beyond it).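

The group on the sulfonyl sulfur can matter after all, which the earlier swap of amino for methyl on the ring gave no sign of. Putting 3,4-dichlorophenyl in place of 4-aminophenyl gives a 3.0-fold higher number from compound 2 to compound 4 (0.48 log units; beyond the scatter) and in place of 4-methylphenyl gives a 2.5-fold higher number from compound 3 to compound 4 (0.40 log units; beyond the scatter), so both steps are modest but lie beyond the scatter. Nothing measured here accounts for this weakening, so its origin stays unexplained.

From the compounds shown here alone, the change brings in two chlorine atoms at once, so it remains open whether 4-chlorophenyl or 3-chlorophenyl alone would give the same result. Also open, going by these compounds, is how this position would respond to a phenyl ring carrying a carboxylic acid, or to a plain alkyl chain in place of the ring.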